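Cytotoxicity of Two Thiazole Analogues and a Proposed Third

The compounds below may be only part of what the source reports. "The series", "measured", "known", "first", "only" and "open" are said of these compounds alone.

compound 1, `CC(C)(C)OC(=O)Nc1ncc(C(Oc2ccc(Br)cc2)c2ccc(Cl)cc2)s1`: > 50000 nM
compound 2, `Cc1ccc(COC(c2ccccc2)c2cnc(NC(=O)c3cccs3)s2)cc1`: "not toxic" (no number reported)

In an ADME assay on HepG2 2.2.15 cells (Homo sapiens) for cytotoxicity (on this read-out higher numbers stand for lower toxicity in this test and lower numbers for higher toxicity in this test), compound 1 gives > 50000 nM, which is a limit of the assay rather than a number. Compound 2 is recorded in this assay as "not toxic" (no number reported), with no number attached, so it stands without a figure. Among the measured compounds shown here, the one other value shown is the limit of > 50000 nM in this assay, at which 1 of the 2 values shown sits. Compound 3, `O=C(Nc1ncc(C(OCc2ccc(F)cc2Br)c2ccccc2)s1)c1cccs1`, differs from compound 2 by 2-bromo-4-fluorophenyl in place of 4-methylphenyl on a saturated chain carbon bound to an oxygen on a saturated carbon. For the measured compounds named here, with no measured step of this kind, no change beyond the usual scatter is expected in this assay. Compound 3 is estimated at 50000 nM, within 20000 nM to 100000 nM, most likely reported again as a limit.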

Compound 3, half-maximal cytotoxic concentration: "not toxic" (no number reported)
Nothing numeric was reported for compound 3, so the estimate cannot be set against anything.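

Compound 2 and compound 3 are both recorded in this assay as "not toxic" without a number, so no step can be read between them. On these data alone, whether 2-bromo-4-fluorophenyl in place of 4-methylphenyl changes the half-maximal cytotoxic concentration at all remains open.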